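Changing one end group of compound 2

The compounds below may be only part of what the source reports. "The series", "measured", "known", "first", "only" and "open" are said of these compounds alone.

Going by the values given here, in a functional assay on ileum (Cavia porcellus) for antagonist activity (a higher number here means a weaker inhibitor, a lower number a stronger inhibitor), compound 2 `Cc1ccccc1OCCCOc1ccc2c(O)c([N+](=O)[O-])c(=O)oc2c1` gives 590 nM as the only true number so far. Compound 1 `COc1ccc(OCCCOc2ccc3c(O)c([N+](=O)[O-])c(=O)oc3c2)cc1` gives > 4000 nM which is a limit of the assay and not a number. Compound 3 `Cc1ccc(OCCCOc2ccc3c(O)c([N+](=O)[O-])c(=O)oc3c2)c([N+](=O)[O-])c1` keeps the same core and chain but has 4-methyl-2-nitrophenyl in place of 2-methylphenyl on an oxygen on a saturated carbon. Among the compounds with values here, one measured step bears on this place: an at least 6.7-fold lower number from compound 1 to compound 2 (0.83 log units; beyond the scatter) on putting 2-methylphenyl in place of 4-methoxyphenyl, which is beyond the scatter and shows that this group can move the number. Starting from compound 2 at 590 nM and with an at least 6.7-fold lower number from compound 1 to compound 2 (0.83 log units; beyond the scatter) as the sole guide, losing 2-methylphenyl is expected to give a modest rise in this assay towards weaker inhibition. The expected change is a 2.2-fold higher number from compound 2 to compound 3 (0.34 log units; beyond the scatter) and a single step supports no firmer forecast. For compound 3 the estimate is 1300 nM with an expected range of 400 nM to 4000 nM at this stage.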

Compound 3, half-maximal inhibitory concentration: > 10000 nM
Compound 3: only a limit was reported; the forecaster's own chance of this, stated with the estimate: 20%; middle value at least 7.6-fold (0.88 log units) away from the limit.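

In this assay, going by these compounds alone, this end group on the oxygen can cost far more than the earlier compounds could show: 4-methyl-2-nitrophenyl in place of 2-methylphenyl gives an at least 16-fold higher number from compound 2 to compound 3 (1.22 log units; beyond the scatter). Compound 3 gives > 10000 nM, which is a limit of the assay and not a number, so this step has a floor but no known full size. The step from compound 1 to compound 3 joins two limits and cannot be read, which leaves compound 2, with its 2-methylphenyl, as the only one of the three with a true number.

The change from compound 2 to compound 3 alters two things at once, adding the nitro group and moving the methyl group, and the compounds shown do not separate them. A 2-nitrophenyl or a 4-methylphenyl group at this place would tell the two apart.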